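Halogen change on the aryl amine of compound 3

The source may report more compounds than this note shows. Statements on the series, on what has been measured and on what is new or still open speak of the compounds shown alone.

- compound 1 `COc1cc(N)c(C(=N)Nc2cccc(Br)c2)cc1OC` gives 300000 nM
- compound 2 `COc1cccc(NC(=N)c2cc(OC)c(OC)cc2N)c1` gives 340000 nM
- compound 3 `COc1cc2c(cc1OC)C(Nc1cccc(Br)c1)=NC(C)(C)N2` gives 130000 nM

In a functional assay on A-431 cells (Homo sapiens) for cytotoxicity (on this read-out lower numbers stand for stronger inhibition and higher numbers for weaker inhibition), compound 3 holds the lowest number of the three, beyond the scatter from both compound 1 and compound 2. Compound 4 `COc1cc2c(cc1OC)C(Nc1ccc(F)c(Cl)c1)=NC(C)(C)N2` carries 3-chloro-4-fluorophenyl in place of 3-bromophenyl on an amine nitrogen. Among the measured compounds shown here, the one measured step on the aryl group is a 1.1-fold higher number from compound 1 to compound 2 (0.05 log units; within the scatter) for methoxy in place of bromo on an aromatic carbon, within the scatter, and it was taken on the core of compound 1. For the measured compounds named here, no measured step covers this exact exchange. A step of a 1.1-fold lower number from compound 3 to compound 4 (0.03 log units; within the scatter) is therefore expected, none beyond the scatter. For compound 4 the estimated value is 120000 nM with an expected range from 50000 nM to 300000 nM.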

Compound 4, half-maximal inhibitory concentration: 90000 nM
Compound 4: middle estimate off by 1.3-fold (0.12 log units), on the high side; measured number inside the range.
By their numbers in this assay, from the lowest: compounds 4 and 3 (each within the scatter of the next); then compounds 1 and 2 (each within the scatter of the next).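

In this assay, 3-chloro-4-fluorophenyl in place of 3-bromophenyl on an amine nitrogen gives a 1.4-fold lower number from compound 3 to compound 4 (0.16 log units; within the scatter), so the aryl group on the shared core of compound 3 tolerates this exchange without a change beyond the scatter. Together with the step on the core of compound 1, this gives two aryl exchanges on two cores, both within the scatter. Nothing available bears on the cause of this result.

From the compounds shown here alone, whether an aryl group carrying an amine or a carboxylic acid would move the number beyond the scatter remains open. Also open, going by these compounds, is whether methoxy behaves on this core as on the core of compound 1.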